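Thiocarbonate and dithiocarbonate aryl ketones: one sulfur-for-oxygen swap

The source may hold more compounds than are shown below. What is called first, only, known or untested is meant among the compounds shown, and "the series" means these compounds.

Measured so far in an assay on HEK293 cells for inhibition of protein deacetylase HDAC6 (Homo sapiens); on this read-out higher numbers stand for weaker inhibition and lower numbers for stronger inhibition:
compound 1 `CCSC(=S)SCC(=O)c1cccc(NS(=O)(=O)c2ccc(Cl)cc2)c1` gives 1250 nM
compound 2 `CCOC(=O)SCC(=O)c1ccc(OC)cc1` gives 5360 nM
compound 3 `COc1ccc(C(=O)CSC(=S)SCCOc2ccccc2)cc1` gives 4570 nM

Compound 2 has the highest number of the three in this assay. Its gap to compound 3 lies within the usual scatter, so the two cannot be ordered; its gap to compound 1 lies beyond the scatter, so compound 1 is the stronger inhibitor of that pair. Within the data shown here, no two of the measured compounds differ in a single place, so no measured step is available for comparison.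

Compound 4 `CCOC(=S)SCC(=O)c1ccc(OC)cc1` has not been measured. It differs from compound 2 as follows: a group of 5 heavy atoms (3 carbon, 1 oxygen, 1 sulfur; no ring) in place of a group of 5 heavy atoms (3 carbon, 2 oxygen; no ring), on a sulfur. The aryl ketone part is unchanged; only the group on the sulfur is exchanged.

Compound 3 carries a sulfur-rich group on the same aryl ketone as compound 2, and compound 3 gives 4570 nM, within the scatter of compound 2. On that basis the expected change from compound 2 to compound 4 is small, a 1.3-fold lower number from compound 2 to compound 4 (0.13 log units; within the scatter), and may be none beyond the scatter. The value expected for compound 4 in this assay is 4000 nM, with a range from 1500 nM to 10000 nM.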

Compound 4, half-maximal inhibitory concentration: 448 nM
Estimate against measurement, compound 4: 8.9-fold (0.95 log units) above; measured number outside the range, below it.
By their numbers in this assay, from the lowest: compound 4; then compound 1; then compounds 3 and 2 (each within the scatter of the next).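

Among these compounds, the exchange of ethoxycarbonyl for the group of 3 carbon, 1 oxygen and 1 sulfur, on a sulfur whose other neighbours are a saturated chain carbon, gives a 12-fold lower number from compound 2 to compound 4 (1.08 log units; beyond the scatter) in this assay, a large step and the first single-place comparison. The earlier compounds offered no such pair, so this position had shown no sensitivity until now, and here the number moves far beyond the scatter although the aryl ketone part stays the same and both groups have the same computed counts of heavy atoms, double bonds outside aromatic rings, hydrogen-bond donors and acceptors, and the same net charge. No measurement shown here accounts for the size of this step.

As far as these compounds go, whether the same exchange gives a step of similar size on the aryl ketone of compound 1 remains open, since this result rests on a single pair. Also open, from the compounds shown here alone, is how the number responds when an amine nitrogen takes the place of the oxygen in the entering group, or when a longer chain replaces its ethyl end.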